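This account rests on a few compounds, and the source may have more. Where it says the series, first, only, none or still open, it means among the compounds named here.

Compound 1 `Cc1nc(S(C)(=O)=O)ccc1Oc1ncnc(OC2CCN(C(=O)OC(C)(C)CF)CC2)c1F`, which in a functional assay on isolated protein for inhibition of Glucose-dependent insulinotropic receptor (Homo sapiens), read by HTRF and cAMP accumulation (a higher number here means that more compound is needed for the effect, a lower number that less compound is needed), gives 19.9 nM.
Compound 2 `Cc1nc(S(C)(=O)=O)ccc1Oc1ncnc(OC2CCN(C(=S)OC(C)C)CC2)c1F`, which in this assay gives 69.9 nM.

Going by the values given here, of the two numbers, compound 2 holds the higher one; the only neighbour is compound 1, and the step of a 3.5-fold higher number from compound 1 to compound 2 (0.55 log units; beyond the scatter) came with a thiocarbonyl in place of a carbonyl bearing a fluorine. Compound 3 `Cc1nc(S(C)(=O)=O)ccc1Oc1ncnc(OC2CCN(C(=O)C(C)(C)F)CC2)c1F` differs from compound 2 by a group of 6 heavy atoms (4 carbon, 1 oxygen, 1 fluorine; no ring) in place of a group of 6 heavy atoms (4 carbon, 1 oxygen, 1 sulfur; no ring), on an amine nitrogen in a ring. Among the compounds with values here, that change brings back both a carbonyl and a fluorine, so the one relevant step, a 3.5-fold higher number from compound 1 to compound 2 (0.55 log units; beyond the scatter), is expected to be partly reversed: a modest downward step, a 2.3-fold lower number from compound 2 to compound 3 (0.37 log units; beyond the scatter), is estimated. Compound 3 is therefore expected to give 30 nM in this assay, with a range from 12 nM to 80 nM.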

Compound 3, half-maximal effective concentration: 76.3 nM
Compound 3: middle estimate off by 2.5-fold (0.41 log units), on the low side, within the range that was stated.
By their numbers in this assay, from the lowest: compound 1; then compounds 2 and 3 (each within the scatter of the next).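

With a carbonyl and a fluorine both back on the amine nitrogen in a ring, compound 3 still does not match compound 1 in this assay, showing a 3.8-fold higher number from compound 1 to compound 3 (0.58 log units; beyond the scatter). The exchange of the thiocarbonyl group for (1-fluoro-1-methylethyl)carbonyl gives a 1.1-fold higher number from compound 2 to compound 3 (0.04 log units; within the scatter), so these two groups cannot be told apart here. No available evidence explains either step.

The compounds leave open whether a cyclopropyl ring or a longer chain on the carbonyl carbon would stand nearer compound 1 or compound 3.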